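Fused pentacyclic series: cytotoxicity on LNCaP cells

The compounds below may be only part of what the source reports. "The series", "measured", "known", "first", "only" and "open" are said of these compounds alone.

Measured compounds:
- compound 1 `c1ccc2nc3c(cc2c1)Cn1c-3nc2ccccc21`: 11300 nM
- compound 2 `Cc1cccc2cc3c(nc12)-c1nc2ccccc2n1C3`: 23800 nM

In a functional assay on LNCaP cells (Homo sapiens) for cytotoxicity, read by MTT assay, with a stated time of 72 h (on this read-out higher numbers stand for weaker inhibition and lower numbers for stronger inhibition), compound 1 gives 11300 nM and compound 2 gives 23800 nM. Among the measured compounds shown here, the single measured step, methyl in place of hydrogen on an aromatic carbon, is a 2.1-fold higher number from compound 1 to compound 2 (0.32 log units; beyond the scatter). For the measured compounds named here, compound 2 thus holds the highest of the two numbers, with compound 1 as its only neighbour.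

Compound 3 `COc1cccc2cc3c(nc12)-c1nc2ccccc2n1C3` is not yet measured in this assay. It differs from compound 2 by methoxy in place of methyl on an aromatic carbon. Going by the values given here, no measured step exchanges methyl for methoxy, so the only precedent at this position is the hydrogen-to-methyl step from compound 1 to compound 2, which was modest. A change of comparable modesty is expected here, with no firm direction, and the number for compound 3 is expected to stay close to that of compound 2: the estimated step is a 1.2-fold lower number from compound 2 to compound 3 (0.08 log units; within the scatter). For compound 3 the expected value in this assay is 20000 nM, with a range from 8000 nM to 60000 nM.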

Compound 3, half-maximal inhibitory concentration: 20000 nM
For compound 3 middle estimate and measured number coincide at the digits printed, within the range that was stated.
By their numbers in this assay, from the lowest: compounds 1, 3 and 2 (each within the scatter of the next, the first and the last beyond it).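

In this assay, methoxy in place of methyl on this aromatic carbon gives a 1.2-fold lower number from compound 2 to compound 3 (0.08 log units; within the scatter) and so does not separate compound 3 from compound 2, even though methoxy adds an oxygen and a hydrogen-bond acceptor that methyl lacks. Methoxy in place of hydrogen gives a 1.8-fold higher number from compound 1 to compound 3 (0.25 log units; within the scatter) and also stays within the scatter, whereas methyl in place of hydrogen gives a 2.1-fold higher number from compound 1 to compound 2 (0.32 log units; beyond the scatter) and just passes it. Hydrogen, methyl and methoxy therefore span a narrow band at this position, and compound 1 and compound 2 are the only pair printed as beyond the scatter of each other, by a modest step.

Still open, as far as these compounds go, is how an amine, a carboxylic acid or a longer chain such as ethoxy on this same aromatic carbon would read, and whether any group here can give a number clearly lower than that of compound 1. No supporting data are available to account for these small steps.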